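From methylsulfanyl to carbamoyl on a shared core

The source may report more compounds than this note shows. Statements on the series, on what has been measured and on what is new or still open speak of the compounds shown alone.

Compound 1 `Cc1cc(NC(=O)Nc2ccc(C)c(Cl)c2)c2ccccc2n1` gives 300 nM
Compound 2 `Cc1cc(NC(=O)Nc2ccc(Cl)c(Cl)c2)c2ccccc2n1` gives 300 nM
Compound 3 `CSc1ccc(NC(=O)Nc2cc(C)nc3ccccc23)cc1` gives 1300 nM

These three values come from a physicochemical assay for solubility, at pH 7.4; a lower number here means a less soluble compound, a higher number a more soluble compound. Compound 3 stands highest of the three, and its gap to compound 1 and to compound 2 is larger than the usual scatter of repeated measurements.

The next structure is compound 4 `Cc1cc(NC(=O)Nc2ccc(C(N)=O)cc2)c2ccccc2n1`. It has carbamoyl in place of methylsulfanyl on an aromatic carbon, para to a large group (carbamoyl in place of methylsulfanyl on an aromatic carbon).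

Among the measured compounds shown here, only one measured step changes a single place, no change at the digits printed from compound 1 to compound 2 (within the scatter), and it is a different exchange: chloro in place of methyl on an aromatic carbon. For the measured compounds named here, that step therefore says little about the new change, and no measured pair shows what happens when methylsulfanyl leaves or carbamoyl enters. With no measured guide to direction or size, the working expectation in this assay is no step beyond the scatter, starting from compound 3 at 1300 nM. The estimated change is a 1.2-fold higher number from compound 3 to compound 4 (0.06 log units; within the scatter), and the uncertainty in either direction is wide. For compound 4 the expected value is 1500 nM, with an estimated range from 400 nM to 5000 nM.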

Compound 4, solubility: 900 nM
For compound 4 the middle estimate is 1.7-fold (0.22 log units) above the measured one; measured number inside the range.
By their numbers in this assay, from the lowest: compounds 1 and 2 (each within the scatter of the next); then compounds 4 and 3 (each within the scatter of the next).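

In this assay, the step for carbamoyl in place of methylsulfanyl, on an aromatic carbon para to a large group, is a 1.4-fold lower number from compound 3 to compound 4 (0.16 log units; within the scatter) and lies within the usual scatter of repeated measurements. Among the compounds shown here, this is the first measured pair that exchanges the group at this position, and it gives a direct reading: this particular exchange, which brings in a hydrogen-bond donor where methylsulfanyl has none, produces no step that can be told apart from scatter. Nothing measured here bears on the reason for this result.

The compounds shown leave open how far this reading extends, since a single pair cannot show whether an amine, a carboxylic acid or a longer chain at the same position would also stay within the scatter of compound 3 and compound 4. For the compounds shown here, it also remains open whether carbamoyl would give a similar reading on a ring that carries the other substituents of compound 1 or compound 2, as no measured pair tests that exchange there.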